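Diaryl thiourea series: removing one chloro from compound 2

The source may report more compounds than this note shows. Statements on the series, on what has been measured and on what is new or still open speak of the compounds shown alone.

Measured so far:
compound 1, `CNC(=O)c1ccc(Oc2cccc(NC(=S)Nc3ccc(C)c(C)c3)c2)nc1` — > 100000 nM
compound 2, `CNC(=O)c1ccc(Oc2cccc(NC(=S)Nc3ccc(Cl)cc3Cl)c2)nc1` — 21600 nM
compound 3, `CNC(=O)c1ccc(Oc2cccc(NC(=S)Nc3ccc(Cl)c(C(F)(F)F)c3)c2)nc1` — 5350 nM

In a functional assay on HepG2 cells (Homo sapiens) for antiproliferative activity, read by MTT assay (on this read-out lower numbers stand for stronger inhibition and higher numbers for weaker inhibition), compound 2 gives 21600 nM, the higher of the two numbers measured in the set; compound 3 gives 5350 nM, a step beyond the scatter. The value of compound 1 is a limit of this assay, > 100000 nM. Within the data shown here, the one step between neighbours, an at least 4.6-fold lower number from compound 1 to compound 2 (0.66 log units; beyond the scatter), shows that the 2,4-dichlorophenyl group brings the number down from the limit at the limit of > 100000 nM in this assay, at which 1 of the 3 values shown sits.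

Compound 4, `CNC(=O)c1ccc(Oc2cccc(NC(=S)Nc3ccc(Cl)cc3)c2)nc1`, has not yet been measured. It differs from compound 2 by hydrogen in place of chloro on an aromatic carbon. Among the measured compounds shown here, no measured step removes a single chloro on its own; the step from compound 1 to compound 2 exchanges the whole substitution pattern, and compound 3 carries a 4-chloro together with a trifluoromethyl. The loss of a substituent from the aryl ring is therefore expected to give a modest rise in the number, a 2.1-fold higher number from compound 2 to compound 4 (0.32 log units; beyond the scatter), with the chance that only a limit is reported. Compound 4 is estimated at 45000 nM, in the range 12000 nM to 150000 nM.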

Compound 4, half-maximal inhibitory concentration: 29400 nM
Estimate against measurement, compound 4: 1.5-fold (0.18 log units) above; the range from low to high includes it.
By their numbers in this assay, from the lowest: compound 3; then compounds 2 and 4 (each within the scatter of the next). At a limit, above all of these: compound 1.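

In this assay, going from 2,4-dichlorophenyl to 4-chlorophenyl gives a 1.4-fold higher number from compound 2 to compound 4 (0.13 log units; within the scatter), so this chloro, ortho to a large group, can give way to hydrogen without a change the assay can resolve. Hydrogen in place of trifluoromethyl gives a 5.5-fold higher number from compound 3 to compound 4 (0.74 log units; beyond the scatter), so on this aryl ring the trifluoromethyl group counts where the chloro ortho to a large group does not. The value of compound 1 is a limit, which leaves an at least 3.4-fold lower number from compound 1 to compound 4 (0.53 log units; beyond the scatter) bounded on one side only: the limit of > 100000 nM in this assay, at which 1 of the 4 values shown sits.

Open, on these data alone, is what a methoxy group or an amine would do in the place of this chloro. Also open, as far as these compounds go, is what the remaining 4-chloro contributes on its own, and whether trifluoromethyl keeps its effect without it.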